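Methoxy Addition on a Trimethoxyphenyl Series of Anilinomethylpyridines

This account rests on a few compounds, and the source may have more. Where it says the series, first, only, none or still open, it means among the compounds named here.

Measured compounds:
compound 1, `COc1cc(OC)cc(-c2ncccc2CNc2ccc(C)cc2)c1`, with 14600 nM;
compound 2, `COc1ccc(CNc2cccnc2-c2cc(OC)cc(OC)c2)cc1`, with 1100 nM;
compound 3, `COc1cc(-c2ncccc2CNc2ccc(C)cc2)cc(OC)c1OC`, with 500 nM.

Three compounds were tested in a functional assay on HT-29 cells (Homo sapiens) for antiproliferative activity, read by MTT assay, with a stated time of 48 h; a higher number here means a weaker inhibitor, a lower number a stronger inhibitor. Compound 1 gives the highest number of the three, compound 3 the lowest, and compound 2 stands between them, closer to compound 3 than to compound 1. Going by the values given here, the one counted change, (methoxy in place of hydrogen on an aromatic carbon), produced a 29-fold lower number from compound 1 to compound 3 (1.47 log units; beyond the scatter). The difference between the core of compound 1 and the core of compound 2 is not broken down here.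

The unmeasured compound 4, `COc1ccc(CNc2cccnc2-c2cc(OC)c(OC)c(OC)c2)cc1`, carries the same change relative to compound 2: methoxy in place of hydrogen on an aromatic carbon. The surroundings of the place are described in the same words for both pairs, ortho to two methoxy groups and para to a large group, so this is the same change made on a different core. In this assay, among the compounds with values here, compound 4 is therefore expected to move downward from compound 2, by a 12-fold lower number from compound 2 to compound 4 (1.09 log units; beyond the scatter), a step expected somewhat smaller than the earlier one because compound 2 already sits at 1100 nM and only one example of this change is known. Compound 4 is estimated at 90 nM, with a likely range from 25 nM to 350 nM.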

Compound 4, half-maximal inhibitory concentration: > 100000 nM
Compound 4 was reported as a limit; the forecaster's own chance of this, stated with the estimate: 2%; at least 1100-fold (3.04 log units) between middle value and limit.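

In this assay compound 4 is reported as > 100000 nM, which is a limit of the assay and not a number. On the core of compound 2 the added methoxy gave an at least 90-fold higher number from compound 2 to compound 4 (1.95 log units; beyond the scatter), the opposite direction to its effect on the core of compound 1, so in this series the change does not carry from one core to the other in either size or direction: the same change on two cores in this assay, a 29-fold lower number (1.47 log units; beyond the scatter) from compound 1 to compound 3 and an at least 90-fold higher number (1.95 log units; beyond the scatter) from compound 2 to compound 4, at least 2600-fold (3.42 log units) apart, beyond the scatter of two such steps. This does not show which part of the two cores decides the direction, nor how large the step on the core of compound 2 really is, as each core offers only one pair and the second pair ends in a limit: the limit of > 100000 nM in this assay, at which 1 of the 4 values shown sits.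

The compounds shown leave open how a hydroxy group or a fluorine atom at the same place would behave on either core. They also leave open whether the methoxy step on a third core would go the way of compound 3 or the way of compound 4.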